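The source may hold more compounds than are shown below. What is called first, only, known or untested is meant among the compounds shown, and "the series" means these compounds.

Measured so far in an ADME assay on the whole organism (strain S2) for cytotoxicity, with Drosophila as the target, read by WST assay; on this read-out higher numbers stand for lower toxicity in this test and lower numbers for higher toxicity in this test:
compound 1, `CCCC(=O)c1c(OC)c(Cl)c(OC)c(Cl)c1OC` — 144000 nM
compound 2, `CCCCCC(=O)c1c(O)c(Cl)c(OC)c(Cl)c1O` — 22500 nM
compound 3, `CCCC(=O)c1c(O)c(Cl)c(O)c(Cl)c1O` — a limit, > 100000 nM

Compound 2 gives the lowest of the two numbers in this assay; compound 1 stands nearest, with a number beyond the scatter above it. Compound 3 sits at the limit of > 100000 nM in this assay, at which 1 of the 3 values shown sits, rather than a number. Among the compounds with values here, no step between measured compounds changes one place only, so no measured step guides the next one.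

Compound 4, `CCCCCC(=O)c1c(O)cc(OC)c(Cl)c1O`, is not yet measured in this assay. It differs from compound 2 by hydrogen in place of chloro on an aromatic carbon. A step of a 2.2-fold higher number from compound 2 to compound 4 (0.35 log units; beyond the scatter) toward a higher number in this assay is expected, small to moderate. Compound 4 is therefore estimated at 50000 nM, in the range 15000 nM to 160000 nM.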

Compound 4, half-maximal cytotoxic concentration: 8700 nM
Estimate against measurement, compound 4: 5.7-fold (0.76 log units) above; measured number outside the range, below it.
By their numbers in this assay, from the lowest: compound 4; then compound 2; then compound 1.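

Hydrogen in place of chloro on this aromatic carbon, ortho to a hydroxy group and ortho to a methoxy group, gives in this assay the step of a 2.6-fold lower number from compound 2 to compound 4 (0.41 log units; beyond the scatter). Within the data shown here, this is the first change of one place only, and it shows that this position affects the read-out, with hydrogen going with higher toxicity in this test. Nothing at hand explains the direction of this step.

Still open, as far as these compounds go, is how an amine or a fluoro group on this aromatic carbon would read. Also open, from the compounds shown here alone, is whether hydrogen in place of the remaining chloro moves the number the same way.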